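The source may report more compounds than this note shows. Statements on the series, on what has been measured and on what is new or still open speak of the compounds shown alone.

Of the compounds shown here, two sharing a core have been measured so far in a functional assay for inhibition, with Rattus norvegicus as the target; a higher number here means a weaker inhibitor, a lower number a stronger inhibitor. Compound 1 `CCOc1c(C(C)O[Si](C)(C)C(C)(C)C)c(OC(C)=O)c2ccccc2c1OC` gives 23900 nM, and compound 2 `CCOC(=O)c1c(CC)c(OC)c2ccccc2c1OC(C)=O` gives 3760 nM. Compound 2 therefore holds the lower of the two numbers, making it the stronger inhibitor of this pair, and the gap lies beyond the usual scatter of repeated measurements. These two compounds differ in more than one place, so their gap cannot be pinned on any single structural change.

The next compound, compound 3 `CCCCCc1c(C(=O)OCC)c(OC(C)=O)c2ccccc2c1OC`, departs from compound 2 in one place, where the ethyl chain becomes a pentyl chain: propyl in place of hydrogen on a saturated chain carbon, two bonds along the chain from an aromatic carbon. Among the measured compounds shown here, no measured pair shows what a change of this kind does, so the only anchor is compound 2 at 3760 nM. With so little to go on, only a small move is expected, no larger than the scatter, with a slight lean towards a lower number. In this assay, the expected step is a 1.3-fold lower number from compound 2 to compound 3 (0.13 log units; within the scatter). For compound 3, the estimated value is 2800 nM, within an expected range of 800 nM to 10000 nM.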

Compound 3, half-maximal inhibitory concentration: 8920 nM
Estimate against measurement, compound 3: 3.2-fold (0.50 log units) below; measured number inside the range.
By their numbers in this assay, from the lowest: compound 2; then compound 3; then compound 1.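

In this assay there is now a comparison that changes one place only, and lengthening the ethyl chain to a pentyl chain gives a 2.4-fold higher number from compound 2 to compound 3 (0.38 log units; beyond the scatter) with everything else in the molecule unchanged. The extra propyl on this saturated chain carbon therefore makes the compound a weaker inhibitor, not a stronger one, so this chain is a place where structure does affect the result. The step is modest, though, and compound 3 keeps measurable inhibition, which means that this position accepts the longer chain at some cost; nothing available here gives a reason for that cost.

A single step cannot show whether the number rises steadily with chain length or jumps at some particular length, and a propyl or butyl chain at this position would help to separate those two possibilities. On these data alone, it also remains open how a shorter methyl group would behave here, or whether a chain of similar length ending in an amine or a carboxylic acid would give a stronger or a weaker inhibitor than compound 2.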